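The source may hold more compounds than are shown below. What is called first, only, known or untested is meant among the compounds shown, and "the series" means these compounds.

Measured so far in a functional assay on MCF7 cells (Homo sapiens) for antiproliferative activity, read by MTT assay, with a stated time of 24 h (on this read-out lower numbers stand for stronger inhibition and higher numbers for weaker inhibition), are two compounds:
- compound 1 `CCN(CC)CCNC(=O)c1cc(C(CC)(CC)c2ccc(OCSC)c(C)c2)cn1CC` at 4640 nM
- compound 2 `CCN(CC)CCNC(=O)c1cc(C(CC)(CC)c2ccc(OCSc3ccccc3)c(C)c2)cn1CC` at 4700 nM

Going by the values given here, compound 2 at 4700 nM stands level with compound 1, the only other measured compound, and the gap between them lies within the scatter. Next in the series is compound 3 `CCN(CC)CCNC(=O)c1cc(C(CC)(CC)c2ccc(OCS(C)(=O)=O)c(C)c2)cn1CC`, with this change: methylsulfonyl in place of phenylsulfanyl on a saturated chain carbon bound to an oxygen on an aromatic ring.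

Among the compounds with values here, one measured step bears on it: a 1.0-fold higher number from compound 1 to compound 2 (0.01 log units; within the scatter) for phenyl in place of methyl on a sulfur. Within the data shown here, no measured compound carries a methylsulfonyl group, so the data hold no direct precedent for the entering group, and a single step is thin support. The expectation rests on compound 2 at 4700 nM and on that one step. In this assay no shift beyond the scatter is expected in either direction, and the expected step is a 1.0-fold higher number from compound 2 to compound 3 (0.01 log units; within the scatter) in this estimate. For compound 3 the estimated value is 4800 nM (expected range 2200 nM to 10000 nM).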

Compound 3, half-maximal inhibitory concentration: 16300 nM
Beside the measured number, compound 3's estimate is 3.4-fold (0.53 log units) below it; the measured number lies above the stated range.
By their numbers in this assay, from the lowest: compounds 1 and 2 (each within the scatter of the next); then compound 3.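

In this assay, the place on a saturated chain carbon bound to an oxygen on an aromatic ring now proves sensitive to what it carries, although exchanging methyl for phenyl on the sulfur had left compound 1 and compound 2 level. Methylsulfonyl in place of phenylsulfanyl gives a 3.5-fold higher number from compound 2 to compound 3 (0.54 log units; beyond the scatter) and so shows weaker inhibition, while methylsulfonyl in place of methylsulfanyl gives a 3.5-fold higher number from compound 1 to compound 3 (0.55 log units; beyond the scatter) and shows a shift of similar size. The second pair keeps the methyl on the sulfur, so the weaker inhibition of compound 3 does not depend on removing the phenyl ring, and the change at the sulfur itself becomes the feature that separates compound 3 from the two sulfanyl compounds.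

Still open, from the compounds shown here alone, is whether a phenylsulfonyl or methylsulfinyl group would behave like methylsulfonyl, and whether an amine or a carboxylic acid at this place would stay level with compound 1 and compound 2 or follow compound 3. The data on hand give no reason for the shift at this place.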